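Swapping the amide substituent in a coumarin amide series

This account rests on a few compounds, and the source may have more. Where it says the series, first, only, none or still open, it means among the compounds named here.

Measured so far:
- compound 1 `CN(C(=O)c1cc2ccccc2oc1=O)c1ccccc1`: 8890 nM in an in vitro assay on BTI-TN-5B1-4 cells for inhibition of Amine oxidase [flavin-containing] B (Homo sapiens), read by fluorescence; on this read-out lower numbers stand for stronger inhibition and higher numbers for weaker inhibition
- compound 2 `CC(C)CNC(=O)c1cc2ccc(OCc3ccccc3)cc2oc1=O`: 9590 nM in this assay

Compound 2 and compound 1 give numbers that lie within the usual scatter of each other, so neither can be called the more potent one. Compound 3 `CN(C(=O)c1cc2ccc(OCc3ccccc3)cc2oc1=O)c1ccccc1` has not been measured yet. It arises from compound 2 by the change (methyl(phenyl)amino in place of isobutylamino on a carbonyl carbon), and it carries the same amide substituent as compound 1. Because compound 1 gives 8890 nM and compound 2 gives 9590 nM, no step beyond the scatter is expected from compound 2 to compound 3 in this assay; the expected step is a 1.1-fold lower number from compound 2 to compound 3 (0.03 log units; within the scatter). Compound 3 is estimated at 9000 nM, within a range of 3000 nM to 27000 nM.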

Compound 3, half-maximal inhibitory concentration: 2370 nM
For compound 3 the middle estimate is 3.8-fold (0.58 log units) above the measured one; the measured number lies below the stated range.
By their numbers in this assay, from the lowest: compound 3; then compounds 1 and 2 (each within the scatter of the next).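

In this assay, compound 1 and compound 2 sit within the scatter of each other, yet they conceal two real effects. With benzyloxy held constant, exchanging isobutylamino for methyl(phenyl)amino on the carbonyl carbon gives a 4.0-fold lower number from compound 2 to compound 3 (0.61 log units; beyond the scatter), and with the methyl(phenyl)amino amide held constant, placing benzyloxy on the aromatic carbon gives a 3.8-fold lower number from compound 1 to compound 3 (0.57 log units; beyond the scatter), so each change counts when the other is present. Nothing measured here accounts for either step.

As far as these compounds go, how benzyloxy acts on the isobutylamino amide remains open. So does whether methoxy in its place, or cyclohexyl in place of the phenyl ring, would give similar steps.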